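Methoxy Replaces Bromo on the Ring Bound to Nitrogen

The source may hold more compounds than are shown below. What is called first, only, known or untested is meant among the compounds shown, and "the series" means these compounds.

Of the compounds shown here, three sharing one core have been tested in an assay on HEK293 cells for displacement of a labelled ligand from metabotropic glutamate receptor 5 (Rattus norvegicus); a higher number here means a weaker inhibitor, a lower number a stronger inhibitor. Compound 1 `O=C(Nc1cc(-c2ccccc2)nn1-c1ccccc1F)c1ccccc1` gives 2700 nM. Compound 2 `O=C(Nc1cc(-c2ccccc2)nn1-c1ccccc1Cl)c1ccccc1` gives 500 nM, and the step of a 5.4-fold lower number from compound 1 to compound 2 (0.73 log units; beyond the scatter) is a modest gain. For compound 3 `O=C(Nc1cc(-c2ccccc2)nn1-c1cccc(Br)c1)c1ccccc1` only a limit is known, > 10000 nM, at which it sits as the evidence the limit of > 10000 nM in this assay, at which 1 of the 3 values shown sits, notes. Compound 3 therefore stands as the weakest of the three, since both an at least 3.7-fold higher number from compound 1 to compound 3 (0.56 log units; beyond the scatter) and an at least 20-fold higher number from compound 2 to compound 3 (1.30 log units; beyond the scatter) lie beyond the scatter.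

Compound 4 `COc1cccc(-n2nc(-c3ccccc3)cc2NC(=O)c2ccccc2)c1` has not been measured in this assay. It differs from compound 3 by methoxy in place of bromo on an aromatic carbon. For the measured compounds named here, no measured step exchanges a bromo for a methoxy: the only change of a substituent, a 5.4-fold lower number from compound 1 to compound 2 (0.73 log units; beyond the scatter), swaps one halogen for another, and the other two steps change the ring as a whole. The expectation for compound 4 therefore leans mainly on the limit reached by compound 3 at > 10000 nM, with room for either direction. Compound 4 is estimated to show 8000 nM, with a range from 2000 nM to 30000 nM. The step of an at least 1.2-fold lower number from compound 3 to compound 4 (0.09 log units; that floor lies within the scatter) is thus expected to stay within the scatter, and a limit rather than a number is a real possibility.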

Compound 4, inhibition constant: 2100 nM
For compound 4 the middle estimate is 3.8-fold (0.58 log units) above the measured one, within the range that was stated.
By their numbers in this assay, from the lowest: compound 2; then compounds 4 and 1 (each within the scatter of the next). At a limit, above all of these: compound 3.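

In this assay this place on the ring, meta to a large group, now carries a real number rather than only a limit: the step of an at least 4.7-fold lower number from compound 3 to compound 4 (0.67 log units; beyond the scatter) shows that the group standing there matters and that a substituent at this place does not by itself abolish displacement of the ligand. For the compounds shown here, the earlier compounds could not show this, as their one exchange of a substituent was between two halogens on a different carbon. Compared as whole rings, 3-methoxyphenyl gives a 1.3-fold lower number from compound 1 to compound 4 (0.11 log units; within the scatter) against 2-fluorophenyl, which leaves the two level, while it gives a 4.2-fold higher number from compound 2 to compound 4 (0.62 log units; beyond the scatter) against 2-chlorophenyl, so that ring keeps its edge. For compound 3 the value remains a limit, so the size of the gain from bromo to methoxy has only a floor: the limit of > 10000 nM in this assay, at which 1 of the 4 values shown sits.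

As far as these compounds go, with only bromo and methoxy at this place, it stays open whether the gain is particular to methoxy or would extend to other groups such as an amine, a hydroxyl or a longer chain like ethoxy. Also open, from the compounds shown here alone, is how methoxy would read on the carbon that holds chloro in compound 2.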